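This account rests on a few compounds, and the source may have more. Where it says the series, first, only, none or still open, it means among the compounds named here.

Compound 1 `Cn1c(=O)c(S(=O)(=O)c2ccc(F)cc2F)cc2cnc(Nc3cccc4[nH]ccc34)nc21` carries a difluorinated arylsulfonyl group on the shared core together with a 1H-indol-4-yl amine. In a functional assay on K562 cells (Homo sapiens) for inhibition, read by trypan blue exclusion, with a stated time of 72 h (on this read-out lower numbers stand for stronger inhibition and higher numbers for weaker inhibition), compound 1 gives 1500 nM. Two single changes branch from it. Compound 2 `Cn1c(=O)c(S(=O)(=O)c2ccc(F)cc2F)cc2cnc(Nc3cnc4[nH]ccc4c3)nc21` differs by a group of 9 heavy atoms (7 carbon, 2 nitrogen; one five-membered aromatic ring with 1 hetero atom, one six-membered aromatic ring with 1 hetero atom) in place of a group of 9 heavy atoms (8 carbon, 1 nitrogen; one five-membered aromatic ring with 1 hetero atom, one six-membered aromatic ring of carbon only), on a nitrogen on an aromatic ring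
, and in this assay compound 2 gives 750 nM, a step of a 2.0-fold lower number from compound 1 to compound 2 (0.30 log units; within the scatter). Compound 3 `Cn1c(=O)c(S(=O)(=O)c2ccc(F)cc2)cc2cnc(Nc3cccc4[nH]ccc34)nc21` differs from compound 1 by hydrogen in place of fluoro on an aromatic carbon
, and in this assay compound 3 gives 750 nM, a step of a 2.0-fold lower number from compound 1 to compound 3 (0.30 log units; within the scatter). Compound 2 and compound 3 therefore sit at the same figure, and neither can be set apart from compound 1 with confidence, since both steps lie within the scatter of repeated measurements.

Compound 4 `Cn1c(=O)c(S(=O)(=O)c2ccc(F)cc2)cc2cnc(Nc3cnc4[nH]ccc4c3)nc21` has not been measured. It differs from compound 3 by a group of 9 heavy atoms (7 carbon, 2 nitrogen; one five-membered aromatic ring with 1 hetero atom, one six-membered aromatic ring with 1 hetero atom) in place of a group of 9 heavy atoms (8 carbon, 1 nitrogen; one five-membered aromatic ring with 1 hetero atom, one six-membered aromatic ring of carbon only), on a nitrogen on an aromatic ring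
, which is the same change as that from compound 1 to compound 2: the place lines read word for word alike, a nitrogen on an aromatic ring whose other neighbours are aromatic carbon. The two cores on which the change is made differ only by hydrogen in place of fluoro on an aromatic carbon, as already noted.

Within the data shown here, the only guide is the one step already seen with this change, a 2.0-fold lower number from compound 1 to compound 2 (0.30 log units; within the scatter), a single pair and a step that itself lies within the scatter; the same change made on compound 3 is expected to give a step of similar size. Compound 4 is therefore estimated at 450 nM in this assay, with the range 200 nM to 1000 nM, which means an expected step of a 1.7-fold lower number from compound 3 to compound 4 (0.22 log units; within the scatter).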

Compound 4, half-maximal inhibitory concentration: 750 nM
Compound 4: the middle estimate sits 1.7-fold (0.22 log units) below what was measured; measured number inside the range.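

In this assay, putting the second two-ring group in place of 1H-indol-4-yl on the core of compound 3 gives no change at the digits printed from compound 3 to compound 4 (within the scatter), and this step agrees with the earlier one on the core of compound 1: the same change on two cores in this assay, a 2.0-fold lower number (0.30 log units; within the scatter) from compound 1 to compound 2 and no change at the digits printed (within the scatter) from compound 3 to compound 4, 2.0-fold (0.30 log units) apart, within the scatter of two such steps. Hydrogen in place of fluoro on an aromatic carbon gives no change at the digits printed from compound 2 to compound 4 (within the scatter), and this step likewise agrees with its earlier counterpart: the same change on two cores in this assay, a 2.0-fold lower number (0.30 log units; within the scatter) from compound 1 to compound 3 and no change at the digits printed (within the scatter) from compound 2 to compound 4, 2.0-fold (0.30 log units) apart, within the scatter of two such steps. Within these four compounds, each change therefore reads the same on both cores as far as the scatter allows, but every step lies within that scatter, so the data do not show that either change has a real effect on this read-out, that the two changes add up, or that they would behave the same way on any other core.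

The compounds shown leave open whether any group at these places would give a step beyond the scatter, such as chloro or methoxy on the arylsulfonyl ring, or morpholine or a plain phenyl ring in place of the two-ring groups on the nitrogen. They also leave open what a longer chain in place of the methyl group on the shared core would do.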